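The source may report more compounds than this note shows. Statements on the series, on what has been measured and on what is new or still open speak of the compounds shown alone.

Compound 1 `CC1CCN(c2c(S(=O)(=O)c3cc(Cl)cc(Cl)c3)cnc3cc(Cl)ccc23)CC1` gives 93% in an assay on isolated protein for displacement of a labelled ligand from metabotropic glutamate receptor 5 (Homo sapiens), with a stated time of 60 min, tested at 1 uM (on this read-out lower numbers stand for less inhibition and higher numbers for more inhibition at the one concentration tested (going by the name of the read-out)), the highest of the three numbers recorded, though only within the usual scatter of compound 2 `Cc1ccc2ncc(S(=O)(=O)c3ccc(C)c(F)c3)c(N3CCC(C)CC3)c2c1`, which gives 91% in this assay, and of compound 3 `COc1ccc2ncc(S(=O)(=O)c3ccc(C)c(Cl)c3)c(N3CCC(C)CC3)c2c1`, which gives 85%. Going by the values given here, no two of these measured compounds differ in a single place, so no measured step is available. Compound 4 `Cc1ccc(S(=O)(=O)c2cnc3cc(Cl)ccc3c2N2CCC(C)CC2)cc1F` differs from compound 1 by 3-fluoro-4-methylphenyl in place of 3,5-dichlorophenyl on a sulfonyl sulfur. Compound 2 already carries the 3-fluoro-4-methylphenyl group on its sulfonyl sulfur and sits close to compound 1, so the step of a number 3 percentage points lower from compound 1 to compound 4 (within the scatter) is expected to be none beyond the scatter. Compound 4 is therefore estimated at 90% in this assay, within a range from 80% to 97%, because compound 2 gives 91%.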

Compound 4, a percentage reported as inhibition, at one concentration (the size of the read-out at that concentration, not a potency): 85%
Compound 4: middle estimate off by 5 percentage points, on the high side, and the stated range covers the measured number.
By their numbers in this assay, from the lowest: compounds 3, 4, 2 and 1 (each within the scatter of the next).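

With 3-fluoro-4-methylphenyl in place of 3,5-dichlorophenyl on a sulfonyl sulfur, this assay shows a number 8 percentage points lower from compound 1 to compound 4 (within the scatter). Going by these compounds alone, this is the first comparison of compounds differing in one place, and it shows that this one exchange on the sulfonyl sulfur leaves the inhibition within the usual scatter. No measurement shown here bears on a cause for this step.

As far as these compounds go, whether a pyridine, or a phenyl ring carrying an amine or a carboxylic acid, would hold the inhibition on the sulfonyl sulfur remains open. So does how the effect of compound 1 and compound 4 compares at any other concentration; only one concentration was tested.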